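This account rests on a few compounds, and the source may have more. Where it says the series, first, only, none or still open, it means among the compounds named here.

Compound 1 `COc1ccc(C(=O)NNc2c(Br)cccc2Br)cc1` has been tested in a toxicity assay on MDCK cells (Canis lupus familiaris) for cytotoxicity, read by CCK-8 assay, with a stated time of 48 h; on this read-out higher numbers stand for lower toxicity in this test and lower numbers for higher toxicity in this test. In this assay compound 1 gives > 100000 nM, which is a limit of the assay rather than a measured number. Compound 2 `CN(C)c1ccc(C(=O)NNc2c(F)cccc2F)cc1` likewise gives > 100000 nM in this assay, again a limit. The picture so far is the limit of > 100000 nM in this assay, at which 2 of the 2 values shown sit. Compound 3 `CN(C)c1ccc(C(=O)NNc2c(Br)cccc2Br)cc1` has not yet been measured; it differs from compound 1 by dimethylamino in place of methoxy on an aromatic carbon. For the measured compounds named here, no step between measured compounds is available to guide the expectation. The step in this assay is expected to be a number no higher from compound 1 to compound 3 (the limit leaves the size open), nothing beyond the usual scatter. Compound 3 is expected to give 100000 nM, with a range from 50000 nM to 300000 nM.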

Compound 3, half-maximal cytotoxic concentration: > 100000 nM
Compound 3 was reported as a limit; the forecaster's own chance of this, stated with the estimate: 85%; the middle value lies on the limit itself.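

Compound 1 and compound 3 both stop at a limit of the assay rather than a measured number, so no step can be read between them: the limit of > 100000 nM in this assay, at which 3 of the 3 values shown sit.

The compounds shown leave open whether dimethylamino in place of methoxy changes the result in this assay at all.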